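The source may report more compounds than this note shows. Statements on the series, on what has been measured and on what is new or still open speak of the compounds shown alone.

Measured in a functional assay on HT-29 cells (Homo sapiens) for inhibition, read by MTT assay, with a stated time of 120 h; on this read-out higher numbers stand for weaker inhibition and lower numbers for stronger inhibition:
compound 1, `CC(NC(=O)/C=C/c1ccc(NC(=O)Nc2ccc(Cl)c(C(F)(F)F)c2)cc1)c1ccccc1`, gives 1060 nM.
compound 2, `CC(NC(=O)/C=C/Oc1ccc(NC(=O)Nc2cc(C(F)(F)F)ccc2Cl)cc1)c1ccccc1`, gives only the assay limit > 50000 nM.
compound 3, `CC(NC(=O)/C=C/Oc1ccc(NC(=O)Nc2ccc(Cl)c(C(F)(F)F)c2)cc1)c1ccccc1`, gives only the assay limit > 50000 nM.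

How the core of compound 1 differs from the core of compound 3 is not broken down here. From compound 3 to compound 2 the change is 2-chloro-5-(trifluoromethyl)phenyl in place of 4-chloro-3-(trifluoromethyl)phenyl on an amide-type nitrogen, and the step is a step that the two limits leave unreadable from compound 3 to compound 2 because both values sit at the limit of > 50000 nM in this assay, at which 2 of the 3 values shown sit. Compound 4, `CC(NC(=O)/C=C/c1ccc(NC(=O)Nc2cc(C(F)(F)F)ccc2Cl)cc1)c1ccccc1`, is not yet measured and carries the same change from compound 1, namely (2-chloro-5-(trifluoromethyl)phenyl in place of 4-chloro-3-(trifluoromethyl)phenyl on an amide-type nitrogen). Among the measured compounds shown here, since the measured pair gives no readable size, the expectation rests only on the single number of compound 1, 1060 nM, and is estimated as a modest loss, a 2.8-fold higher number from compound 1 to compound 4 (0.45 log units; beyond the scatter), with wide uncertainty. Compound 4 is therefore expected to give about 3000 nM in this assay, estimated between 800 nM and 15000 nM.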

Compound 4, half-maximal inhibitory concentration: 4190 nM
Compound 4: middle estimate off by 1.4-fold (0.15 log units), on the low side; low and high end bracket the measured number.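

In this assay, 2-chloro-5-(trifluoromethyl)phenyl in place of 4-chloro-3-(trifluoromethyl)phenyl on an amide-type nitrogen gives a 4.0-fold higher number from compound 1 to compound 4 (0.60 log units; beyond the scatter). The same change from compound 3 to compound 2 cannot be read, since both compounds stand at an assay limit and not at a number: the limit of > 50000 nM in this assay, at which 2 of the 4 values shown sit. The one readable step therefore holds for the core of compound 1 alone, and whether the change has a similar size on the core of compound 3 is not shown.

The compounds shown leave open what an amine or a carboxylic acid in place of the chlorine would give on either core.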